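Nitro for Cyano on Two Androgen-Receptor Antagonist Cores

A few compounds are considered here, and "the series" means these few. Any claim that something is new, unique, unknown or untested is made for them only; others in the source may bear on it.

Measured compounds:
compound 1 `CC(O)(CSc1cc(C(F)(F)F)cc(C(F)(F)F)c1)C(=O)Nc1ccc(C#N)cc1C(F)(F)F` — 4650 nM
compound 2 `CC(O)(CSc1cc(C(F)(F)F)cc(C(F)(F)F)c1)C(=O)Nc1ccc([N+](=O)[O-])cc1C(F)(F)F` — 2290 nM
compound 3 `CC1(C)C(=O)N(c2ccc(C#N)c(C(F)(F)F)c2)C(=S)N1c1cc(C(F)(F)F)cc(C(F)(F)F)c1` — "nd(insoluble)" (no result reported)

In a functional assay on CWR22R cells (Homo sapiens) for antiproliferative activity, read by fluorescence and propidium iodide staining, with a stated time of 96 h (on this read-out higher numbers stand for weaker inhibition and lower numbers for stronger inhibition), compound 1 gives 4650 nM and compound 2 gives 2290 nM. The change between them is nitro in place of cyano on an aromatic carbon, and it brought a 2.0-fold lower number from compound 1 to compound 2 (0.31 log units; beyond the scatter). In this assay compound 3 gives "nd(insoluble)" (no result reported), that is, no number. Compound 4 `CC1(C)C(=O)N(c2ccc([N+](=O)[O-])c(C(F)(F)F)c2)C(=S)N1c1cc(C(F)(F)F)cc(C(F)(F)F)c1` carries the same kind of change on the core of compound 3, namely (nitro in place of cyano on an aromatic carbon); here the group sits ortho to a trifluoromethyl group, whereas in compound 2 it sits meta to one. The difference between the two cores is not broken down here. With no value for compound 3, the expectation for compound 4 rests only on compound 1 and compound 2 and on a 2.0-fold lower number from compound 1 to compound 2 (0.31 log units; beyond the scatter). Compound 4 is estimated at 2500 nM, expected to fall between 300 nM and 20000 nM, with a real chance that it too gives no number.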

Compound 4, half-maximal inhibitory concentration: 20200 nM
For compound 4 the middle estimate is 8.1-fold (0.91 log units) below the measured one; measured number outside the range, above it.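

Compound 3 has no number in this assay, and the step from it to compound 4 cannot be read. From the compounds shown here alone, whether nitro in place of cyano acts alike on both cores stays open. No further data here explain the value of compound 4.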